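The compounds below may be only part of what the source reports. "The series", "measured", "known", "first", "only" and "open" are said of these compounds alone.

Measured compounds:
compound 1 `O=S(=O)(Nc1ccc(Cl)c(Cl)c1)c1ccc(-c2cnc(C3CC3)o2)cc1` — 416 nM
compound 2 `O=S(=O)(Nc1cccc(Cl)c1)c1ccc(-c2cnc(C3CC3)o2)cc1` — 477 nM

In a functional assay on cells (leukaemia cell line, Homo sapiens) for inhibition, read by sulforhodamine B assay, with a stated time of 48 h (a lower number here means a stronger inhibitor of growth, a higher number a weaker inhibitor of growth), compound 1 gives 416 nM and compound 2 gives 477 nM. The step of a 1.1-fold higher number from compound 1 to compound 2 (0.06 log units; within the scatter) arises from hydrogen in place of chloro on an aromatic carbon, so compound 2 stands alongside compound 1, the two numbers within the scatter of each other.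

Compound 3 `Cc1cc(Cl)ccc1NS(=O)(=O)c1ccc(-c2cnc(C3CC3)o2)cc1` differs from compound 2 by 4-chloro-2-methylphenyl in place of 3-chlorophenyl on a sulfonamide nitrogen. Going by the values given here, the only measured step, a 1.1-fold higher number from compound 1 to compound 2 (0.06 log units; within the scatter), also alters the aryl group on the sulfonamide nitrogen and moved the number by less than the scatter. No measured compound carries a methyl on that ring, so nothing shown speaks to that part of the change. On the evidence of compound 2 and of a 1.1-fold higher number from compound 1 to compound 2 (0.06 log units; within the scatter), the step of a 1.1-fold lower number from compound 2 to compound 3 (0.03 log units; within the scatter) is expected to fall within the scatter, in no particular direction. Compound 3 is therefore estimated at 450 nM, with a range of 200 nM to 1000 nM in this assay.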

Compound 3, concentration for 50% growth inhibition: 277 nM
Estimate against measurement, compound 3: 1.6-fold (0.21 log units) above; measured number inside the range.
By their numbers in this assay, from the lowest: compounds 3, 1 and 2 (each within the scatter of the next).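

In this assay the step to 4-chloro-2-methylphenyl on a sulfonamide nitrogen stays small: a 1.7-fold lower number from compound 2 to compound 3 (0.24 log units; within the scatter) and a 1.5-fold lower number from compound 1 to compound 3 (0.18 log units; within the scatter) are both within the scatter. The earlier compounds shown here showed only the loss of one chloro group at this position, whereas compound 3 shows that a different chloro placement combined with an added methyl also leaves the number within the scatter of both neighbours, so all three aryl groups cannot be told apart here. Nothing available bears on why these steps are small.

Because chloro placement and methyl change together in compound 3, their separate contributions cannot be read from these compounds. Also open, as far as these compounds go, is whether a different kind of group on that ring, such as an amine or a carboxylic acid, would keep the number within this range.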